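Swapping Chlorines for Fluorines on a Pyrazole Chalcone

The source may hold more compounds than are shown below. What is called first, only, known or untested is meant among the compounds shown, and "the series" means these compounds.

Compound 2 `COc1cc(-c2cc(/C=C/C(=O)c3ccc(Cl)c(Cl)c3)[nH]n2)cc(OC)c1OC` and compound 1 `COc1ccc(-c2cc(/C=C/C(=O)c3ccc(N)cc3)[nH]n2)cc1` share a core that carries a carbonyl-linked aryl ring. In a functional assay on NCI-H522 cells (Homo sapiens) for inhibition, read by sulforhodamine B assay, with a stated time of 48 h (on this read-out higher numbers stand for weaker inhibition of growth and lower numbers for stronger inhibition of growth), compound 2 gives 3040 nM, and compound 1 gives 2910 nM; these two numbers lie within the usual scatter of each other, so neither stands apart. Compound 3 `COc1cc(-c2cc(/C=C/C(=O)c3ccc(F)c(F)c3)[nH]n2)cc(OC)c1OC` is the unmeasured partner of compound 2, differing by 3,4-difluorophenyl in place of 3,4-dichlorophenyl on a carbonyl carbon. Among the compounds with values here, no measured step of this kind is available here, so the expected change is uncertain; a modest move toward weaker growth inhibition seems most likely, as estimated by a 1.6-fold higher number from compound 2 to compound 3 (0.22 log units; within the scatter). For compound 3 the estimated value in this assay is 5000 nM, with a range from 2000 nM to 15000 nM.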

Compound 3, concentration for total growth inhibition: 4480 nM
Compound 3: the middle estimate sits 1.1-fold (0.05 log units) above what was measured; the range from low to high includes it.
By their numbers in this assay, from the lowest: compounds 1, 2 and 3 (each within the scatter of the next).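

Within the data shown here, this is the first step that changes a single place: with 3,4-difluorophenyl in place of 3,4-dichlorophenyl on the carbonyl carbon, this assay shows a 1.5-fold higher number from compound 2 to compound 3 (0.17 log units; within the scatter). This position therefore accepts either halogen pair with no change that can be told from the scatter. No measurement at hand speaks to the reason for this result.

As far as these compounds go, whether a more different group on this carbonyl carbon, such as plain phenyl or a phenyl ring carrying a carboxylic acid, would move the number beyond the scatter stays open. So does whether the same swap would behave alike with other substituents on the far aryl ring.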